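The source may report more compounds than this note shows. Statements on the series, on what has been measured and on what is new or still open speak of the compounds shown alone.

Of the compounds shown here, three built on one shared core have been measured in a functional assay on the whole organism (Tail, strain ICR) with Mus musculus as the target, in the tail flick test, with a stated time of 150 min, at a dose of 25 umol/kg by the oral route; a higher number here means a stronger effect of the compound at the dose given, a lower number a weaker effect. Compound 1 `O=C(O)[C@@H]1CCCN1C(=O)CN(c1nc(Cl)nc2[nH]cnc12)C1CC1` gives 7.29%. Compound 3 `O=C(OCc1ccccc1)[C@@H]1CCCN1C(=O)CN(c1nc(Cl)nc2[nH]cnc12)C1CC1` gives 31.1%. Between these two lies the only single-point step in the set, a number 23.8 percentage points higher from compound 1 to compound 3 (beyond the scatter). Compound 2 `O=C(CN(c1nc(Cl)nc2[nH]cnc12)C1CC1)NCC(=O)OCc1ccccc1` gives 18%, the second highest of the three numbers; its nearest neighbour is compound 1, whose number is lower beyond the scatter, and the furthest is compound 3, whose number is higher beyond the scatter.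

Compound 4 `NCCCC[C@H](NC(=O)CN(c1nc(Cl)nc2[nH]cnc12)C1CC1)C(=O)OCc1ccccc1` has not yet been measured in this assay. It differs from compound 2 in a single place: 4-aminobutyl in place of hydrogen on a saturated chain carbon bound to an amide-type nitrogen and a carbonyl carbon. Going by the values given here, no measured step bears on this change. Among the compounds with values here, the one step in hand concerns the benzyl group on oxygen, which compound 2 and compound 4 both carry, so it offers no guide to the size or direction of what the new chain might do. The step is therefore expected to be a number 2 percentage points higher from compound 2 to compound 4 (within the scatter), quite possibly within the scatter. For compound 4 the estimate in this assay is 20%, with a range from 5% to 40%.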

Compound 4, a percentage reported as activity, at one dose (the size of the read-out at that dose, not a potency): 9.88%
Estimate against measurement, compound 4: 10.1 percentage points above; measured number inside the range.
By their numbers in this assay, from the lowest: compounds 1, 4 and 2 (each within the scatter of the next, the first and the last beyond it); then compound 3.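

Placing 4-aminobutyl on the saturated chain carbon bound to an amide-type nitrogen and a carbonyl carbon gives a number 8.1 percentage points lower from compound 2 to compound 4 (within the scatter) in this assay. Going by these compounds alone, this is the first look at this position in the set, and it shows that the position carries this chain with no difference that can be told from the usual scatter at this dose and time. No evidence at hand bears on this result.

A shorter chain, a longer chain or a chain carrying a carboxylic acid at this same carbon could still give a different read-out, as could an amide in place of the free amine. Going by these compounds, it also remains open whether a carboxylic acid in place of the benzyl ester of compound 4 would shift the number as it does in the step of a number 23.8 percentage points higher from compound 1 to compound 3 (beyond the scatter), read in reverse.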